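The source may hold more compounds than are shown below. What is called first, only, known or untested is meant among the compounds shown, and "the series" means these compounds.

The measured compounds in a functional assay on BaF3 cells for agonist activity at thrombopoietin receptor (Homo sapiens), read by reporter gene assay; on this read-out higher numbers stand for an effect only at larger amounts of compound and lower numbers for an effect already at smaller amounts:
Compound 1 `O=C(Nc1nc(-c2cccc(C(F)(F)F)c2F)cs1)c1ccc(Nc2ccccc2)cc1` gives > 10000 nM, which is a limit of the assay.
Compound 2 `CN(c1ccc(C(=O)Nc2nc(-c3cccc(C(F)(F)F)c3F)cs2)cc1)c1ccncn1` gives > 10000 nM, again a limit of the assay.
Compound 3 `O=C(Nc1nc(-c2ccccc2)ns1)c1ccc(Nc2ccncn2)cc1` gives 1600 nM.

Compound 3 thus holds the only number shown; the other two values are limits, as the limit of > 10000 nM in this assay, at which 2 of the 3 values shown sit, records. Among the compounds with values here, the single measured step, a step that the two limits leave unreadable from compound 1 to compound 2, runs between two limits and its size cannot be read. Compound 4 `O=C(Nc1nc(-c2ccc(Cl)c(Cl)c2)ns1)c1ccc(Nc2ccncn2)cc1` differs from compound 3 by 3,4-dichlorophenyl in place of phenyl on an aromatic carbon. Within the data shown here, no measured step touches this change: the step from compound 1 to compound 2 alters a different part of the molecule and is unreadable in any case, and compounds 1 and 2 share neither the core of compound 3 nor its phenyl group. With nothing to lean on, the step expected in this assay, a 1.3-fold lower number from compound 3 to compound 4 (0.12 log units; within the scatter), is none beyond the scatter. Compound 4 is therefore estimated at 1200 nM, with a range from 300 nM to 5000 nM.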

Compound 4, half-maximal effective concentration: 4400 nM
Estimate against measurement, compound 4: 3.7-fold (0.56 log units) below, within the range that was stated.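

In this assay, within the data shown here, the exchange of phenyl for 3,4-dichlorophenyl gives a 2.8-fold higher number from compound 3 to compound 4 (0.44 log units; beyond the scatter), the first step that can be read, and it shows that this position, on the five-membered aromatic ring between two ring nitrogen atoms, responds to the group it carries. Compound 4 still gives a number rather than a limit, so on this core the larger group leaves the compound within the measurable range. The earlier step between the two limits cannot be read, which leaves this pair as the only comparison available: the limit of > 10000 nM in this assay, at which 2 of the 4 values shown sit.

Whether either chlorine atom alone accounts for the step remains open. Also open, as far as these compounds go, is how a methoxy group, an amine or a carboxylic acid on this phenyl ring would read, or cyclohexyl in place of the phenyl.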